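From hexyl to phenyl on a saturated chain carbon

The source may hold more compounds than are shown below. What is called first, only, known or untested is meant among the compounds shown, and "the series" means these compounds.

- compound 1 `C=C(CO)C(CCCCCC)n1cnc2c(Cl)ncnc21`: 30200 nM
- compound 2 `C=C(CO)C(CCCCCCCC)n1cnc2c(Cl)ncnc21`: 19400 nM
- compound 3 `C=C(CO)C(CCCCCCCCC)n1cnc2c(Cl)ncnc21`: > 50000 nM, a limit of the assay

In a functional assay on HCT-116 cells (Homo sapiens) for antiproliferative activity, read by MTT assay, with a stated time of 48 h (on this read-out higher numbers stand for weaker inhibition and lower numbers for stronger inhibition), compound 1 gives 30200 nM, which lies within the scatter of compound 2 at 19400 nM. Compound 3 returns only a limit, > 50000 nM.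

Compound 4 `C=C(CO)C(c1ccccc1)n1cnc2c(Cl)ncnc21` differs from compound 1 at one place: phenyl in place of hexyl on a saturated chain carbon bound to an aromatic nitrogen and a double-bonded chain carbon. It carries phenyl in place of hexyl on a saturated chain carbon bound to an aromatic nitrogen and a double-bonded chain carbon.

The nearest evidence comes from the chain steps. One is a 1.6-fold lower number from compound 1 to compound 2 (0.19 log units; within the scatter). Another is an at least 1.6-fold higher number from compound 1 to compound 3 (0.21 log units; that floor lies within the scatter). Only an at least 2.5-fold higher number from compound 2 to compound 3 (0.41 log units; beyond the scatter) passes beyond the scatter, and it ends at a limit. None of these steps replaces a chain with a ring, so they offer only a loose guide, and no clear shift is expected in this assay.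

The expected change is a 1.2-fold higher number from compound 1 to compound 4 (0.06 log units; within the scatter), which would not pass beyond the scatter. For compound 4 the estimated value is 35000 nM, with an expected range from 13000 nM to 90000 nM.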

Compound 4, half-maximal inhibitory concentration: 33300 nM
The estimate for compound 4 lay 1.1-fold (0.02 log units) above the measured number; low and high end bracket the measured number.
By their numbers in this assay, from the lowest: compounds 2, 1 and 4 (each within the scatter of the next). At a limit, above all of these: compound 3.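

In this assay the change from hexyl to phenyl on this carbon gives a 1.1-fold higher number from compound 1 to compound 4 (0.04 log units; within the scatter) and so shows that a six-membered aromatic ring of carbon only can take the place of the saturated chain without a shift beyond the scatter. Within the data shown here, the earlier compounds varied only the chain length, so this is the first sign that activity at this position does not depend on an open chain. Compound 3 remains the only compound at a limit of the assay, and compound 4 gives a readable number: the limit of > 50000 nM in this assay, at which 1 of the 4 values shown sits.

The compounds shown leave open whether a methoxy group or a fluorine on the phenyl ring would move the number beyond the scatter. They also leave open how a pyridyl ring or a much shorter group such as methyl would behave on this carbon.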